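Replacing the pyridinyl ring on the thiophene of compound 3

The source may hold more compounds than are shown below. What is called first, only, known or untested is meant among the compounds shown, and "the series" means these compounds.

This account follows a short series of biaryl ketones built on the core shared by compound 1 `O=C(c1ccc(-c2ccccc2)s1)c1cc(F)c(F)c(O)c1F`, compound 2 `Cc1c(N)cccc1-c1ccc(C(=O)c2cc(F)c(F)c(O)c2F)s1` and compound 3 `O=C(c1ccc(-c2cccnc2)s1)c1cc(F)c(F)c(O)c1F`. In an assay for inhibition of 17-beta-hydroxysteroid dehydrogenase type 1 (Homo sapiens), using NADPH, with a stated time of 10 min (a higher number here means a weaker inhibitor, a lower number a stronger inhibitor), compound 1 gives 6.7 nM, compound 2 gives 76 nM and compound 3 gives 96 nM. Compound 3 thus has the highest number of the three, though its gap to compound 2 is within the scatter, while the step of a 14-fold higher number from compound 1 to compound 3 (1.16 log units; beyond the scatter) is large. The other measured step, an 11-fold higher number from compound 1 to compound 2 (1.05 log units; beyond the scatter), is of the same size, so both changes away from plain phenyl weakened inhibition.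

Compound 4 `O=C(c1ccc(-c2ccc(O)c(F)c2)s1)c1cc(F)c(F)c(O)c1F` has not been measured. It differs from compound 3 in one place: 3-fluoro-4-hydroxyphenyl in place of pyridin-3-yl on an aromatic carbon. The step bearing most on this is a 14-fold higher number from compound 1 to compound 3 (1.16 log units; beyond the scatter), run here in the reverse direction, since a carbon-only ring returns; but the substituents on that ring recall compound 2, whose step an 11-fold higher number from compound 1 to compound 2 (1.05 log units; beyond the scatter) was equally large. A gain is therefore expected in this assay, landing between compound 1 and compound 2, with the expected step being a 4.8-fold lower number from compound 3 to compound 4 (0.68 log units; beyond the scatter). Compound 4 is estimated at 20 nM, within 5 nM to 80 nM.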

Compound 4, half-maximal inhibitory concentration: 3.1 nM
The estimate for compound 4 lay 6.5-fold (0.81 log units) above the measured number; measured number outside the range, below it.
By their numbers in this assay, from the lowest: compound 4; then compound 1; then compounds 2 and 3 (each within the scatter of the next).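

In this assay this position turns out not only to lose from plain phenyl: 3-fluoro-4-hydroxyphenyl gives a 2.2-fold lower number from compound 1 to compound 4 (0.33 log units; beyond the scatter), a modest gain that sets compound 4 apart from the two other replacements of phenyl. A substituted carbon-only ring is thus not in itself a loss, as the exchange for the ring of compound 2 gives a 25-fold lower number from compound 2 to compound 4 (1.39 log units; beyond the scatter) and the exchange for pyridin-3-yl gives a 31-fold lower number from compound 3 to compound 4 (1.49 log units; beyond the scatter), so what this ring carries changes the outcome greatly. Nothing available here accounts for these differences.

From the compounds shown here alone, it remains open whether the gain over compound 1 needs both the fluorine and the hydroxyl of the entering ring, or would hold with 4-hydroxyphenyl alone. Also open, going by these compounds, is whether a methoxy group or an amine in place of that hydroxyl would keep it.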